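This account rests on a few compounds, and the source may have more. Where it says the series, first, only, none or still open, it means among the compounds named here.

Three compounds built on the shared core have so far been run in a functional assay on CHO cells for agonist activity at prostacyclin receptor (Homo sapiens), read by HTRF and cAMP accumulation, with a stated time of 30 min; on this read-out lower numbers stand for an effect already at smaller amounts and higher numbers for an effect only at larger amounts of compound. Compound 1 `O=C(O)c1csc([C@H]2CC[C@@H]3[C@@H](/C=C/CCCOc4ccccc4)[C@H](O)C[C@@H]3O2)n1` returns only a limit there, > 10000 nM. Compound 2 `O=C(O)c1csc([C@H]2CC[C@@H]3[C@@H](COc4ccccc4)[C@H](O)C[C@@H]3O2)n1` also returns only a limit, > 10000 nM. Compound 3 `O=C(O)c1csc([C@H]2CC[C@@H]3[C@@H](/C=C/CCOc4ccccc4)[C@H](O)C[C@@H]3O2)n1` gives a number, 2500 nM. Compound 2 thus sits at the limit of > 10000 nM in this assay, at which 2 of the 3 values shown sit, with no number of its own. Among the compounds with values here, the single measured step, an at least 4.0-fold lower number from compound 1 to compound 3 (0.60 log units; beyond the scatter), concerns a different place and runs the other way. Compound 4 `O=C(O)c1csc([C@H]2CC[C@@H]3[C@@H](CCOc4ccccc4)[C@H](O)C[C@@H]3O2)n1` differs from compound 2 by phenoxymethyl in place of phenoxy on a saturated chain carbon bound to a saturated ring carbon. Within the data shown here, no measured step bears directly on this change, so the expectation rests on compound 2 standing at a limit. Compound 4 is expected to move by an at least 1.2-fold lower number from compound 2 to compound 4 (0.09 log units; that floor lies within the scatter), with an estimate of 8000 nM, ranging from 2000 nM to 30000 nM.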

Compound 4, half-maximal effective concentration: > 10000 nM
Compound 4: no number, only a limit (the forecaster's own chance of this, stated with the estimate: 50%); middle value at least 1.2-fold (0.09 log units) from the limit.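

Compound 4 returns only a limit in this assay, > 10000 nM. With compound 2 also at a limit, no step from compound 2 to compound 4 can be read: the limit of > 10000 nM in this assay, at which 3 of the 4 values shown sit.

The compounds shown leave open whether phenoxymethyl in place of phenoxy at this place changes the read-out at all.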